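The source may hold more compounds than are shown below. What is called first, only, known or untested is meant among the compounds shown, and "the series" means these compounds.

Measured in an ADME assay on CEMx174 cells (Homo sapiens) for cytotoxicity; a lower number here means that less compound is tolerated, a higher number that more compound is tolerated:
- compound 1 `CC1=C(C(=O)OCC2CCCCC2)C(c2ccccc2O)NC(=O)N1`: > 10000 nM
- compound 2 `CCC1=C(C(=O)OCC2CCCCC2)C(c2ccc(N)cc2)NC(=O)N1`: > 10000 nM

Compound 2 stands at > 10000 nM, which is a limit of the assay and not a number. The whole picture so far is the limit of > 10000 nM in this assay, at which 2 of the 2 values shown sit.

Compound 3 `CCC1=C(C(=O)OCC2CCCCC2)C(c2ccc(F)cc2)NC(=O)N1` keeps the rest of compound 2 and carries fluoro in place of amino on an aromatic carbon, para to a large group: fluoro in place of amino on an aromatic carbon. Within the data shown here, no measured pair shows what this swap does, so no step beyond the usual scatter is expected in this assay. The estimate means an expected step that the limit leaves unreadable from compound 2 to compound 3. The expected value for compound 3 is 15000 nM, with an estimated range of 7000 nM to 40000 nM.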

Compound 3, half-maximal cytotoxic concentration: > 10000 nM
Compound 3 ended at the assay's limit; the forecaster's own chance of this, stated with the estimate: 85%; the middle value is on the limit's open side.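

In this assay, among these compounds, compound 2 and compound 3 both sit at a limit of the assay and not at a number; no step between them can be read. The compounds shown leave open at what concentration any of them becomes cytotoxic, and whether fluoro in place of amino alters that concentration.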